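Methyl for methoxy on the phenyl ring: compound 3 to compound 4

The source may report more compounds than this note shows. Statements on the series, on what has been measured and on what is new or still open speak of the compounds shown alone.

Compound 3 `CCC(C(=O)N1CCN(c2cccc(OC)c2)CC1)N1C(=O)CCC1=O` stands with compound 1 `COc1cccc(N2CCN(C(=O)C(C)N3C(=O)CCC3=O)CC2)c1` at the low end of the three numbers: in a functional assay on the whole organism (strain Swiss) with Mus musculus as the target, in the maximal electroshock model, with a stated time of 1 h, at a dose of 300 mg/kg by the intraperitoneal route (on this read-out lower numbers stand for a weaker effect and higher numbers for a stronger effect at the one dose given), compound 3 gives 0%, compound 1 gives 0%, and compound 2 `COCC(C(=O)N1CCN(c2cccc(C(F)(F)F)c2)CC1)N1C(=O)CCC1=O` gives 100%. For the measured compounds named here, the one measured step, no change at the digits printed from compound 1 to compound 3 (within the scatter), concerns the chain and not the aromatic ring, so it does not bear on the present change. Compound 4 `CCC(C(=O)N1CCN(c2cccc(C)c2)CC1)N1C(=O)CCC1=O` differs from compound 3 by methyl in place of methoxy on an aromatic carbon. Going by the values given here, no measured pair isolates this change; compound 2 carries trifluoromethyl and a different chain, so its value cannot be read across. Compound 4 is therefore expected to stay near the floor, with a step of a number 20 percentage points higher from compound 3 to compound 4 (beyond the scatter), an estimated 20% in the range 0% to 70%.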

Compound 4, a percentage reported as activity, at one dose (the size of the read-out at that dose, not a potency): 75%
For compound 4 the middle estimate is 55 percentage points below the measured one; measured number above the stated range.
By their numbers in this assay, from the lowest: compounds 1 and 3 (each within the scatter of the next); then compound 4; then compound 2.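

Methyl in place of methoxy on an aromatic carbon, meta to a large group, gives a number 75 percentage points higher from compound 3 to compound 4 (beyond the scatter) in this assay, the first single-place change in the series to lift the read-out, whereas the chain change gave no change at the digits printed from compound 1 to compound 3 (within the scatter). This aromatic position therefore responds strongly at the one dose given. Nothing available explains the size of this step.

From the compounds shown here alone, whether a chlorine atom or an ethyl group at this place would keep the read-out stays open. Also open, going by these compounds, is whether the methyl gain holds on the chain of compound 1.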